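The source may report more compounds than this note shows. Statements on the series, on what has been measured and on what is new or still open speak of the compounds shown alone.

Measured compounds in an assay on Sf9 cells for inhibition of serine/threonine-protein kinase 4 (Homo sapiens), read by luminescence and ADP-Glo, with a stated time of 1 h, in the presence of a further agent that is not named here; on this read-out higher numbers stand for weaker inhibition and lower numbers for stronger inhibition:

Compound 1 `CN1C(=O)C(C2CC2)N(C)c2nc(Nc3ccc(S(N)(=O)=O)cc3)ncc21` gives 136 nM.
Compound 2 `CC1C(=O)N(C)c2cnc(Nc3ccc(S(N)(=O)=O)cc3)nc2N1C` gives 313 nM.
Compound 3 `CCCC1C(=O)N(C)c2cnc(Nc3ccc(S(N)(=O)=O)cc3)nc2N1C` gives 206 nM.

Compound 2 gives the highest number of the three, though it is separated from compound 3 only by a 1.5-fold lower number from compound 2 to compound 3 (0.18 log units; within the scatter), which is within the scatter, while the step of a 2.3-fold higher number from compound 1 to compound 2 (0.36 log units; beyond the scatter) lies beyond it.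

Compound 4 `CN1C(=O)C(CC2CC2)N(C)c2nc(Nc3ccc(S(N)(=O)=O)cc3)ncc21` is compound 2 with one change: cyclopropyl in place of hydrogen on a saturated chain carbon bound to a saturated ring carbon. Among the measured compounds shown here, two measured steps bear on this. The step of a 1.5-fold lower number from compound 2 to compound 3 (0.18 log units; within the scatter), which also adds carbon at the same place, gave a number inside the usual scatter. The step of a 2.3-fold higher number from compound 1 to compound 2 (0.36 log units; beyond the scatter) shows that a cyclopropyl directly on the ring carbon gives a lower number than a methyl there. Together these suggest that growing the group on the chain carbon lowers the number somewhat, but likely not far.

The expectation for compound 4 in this assay is therefore a small downward step, a 1.6-fold lower number from compound 2 to compound 4 (0.22 log units; within the scatter), with compound 4 estimated at 190 nM and a range from 95 nM to 380 nM.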

Compound 4, half-maximal inhibitory concentration: 211 nM
Beside the measured number, compound 4's estimate is 1.1-fold (0.05 log units) below it, within the range that was stated.
By their numbers in this assay, from the lowest: compounds 1, 3, 4 and 2 (each within the scatter of the next, the first and the last beyond it).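

In this assay, cyclopropyl on a saturated chain carbon bound to a saturated ring carbon stays within the scatter of hydrogen at that place (a 1.5-fold lower number from compound 2 to compound 4 (0.17 log units; within the scatter)) and of ethyl there (a 1.0-fold higher number from compound 3 to compound 4 (0.01 log units; within the scatter)). Cyclopropylmethyl in place of cyclopropyl on a saturated ring carbon also stays within the scatter (a 1.6-fold higher number from compound 1 to compound 4 (0.19 log units; within the scatter)), so a three-membered carbon ring at the end of this group brings no change that these numbers can resolve. No measurement here offers an explanation for this result.

The compounds shown leave open whether a phenyl ring or a much longer chain at this place would also stay within the scatter. They also do not show whether an amine or a carboxylic acid on this chain would shift the number in either direction.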